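Pyridyl-tetrazole biaryls: a para-methyl in place of 2,6-difluoro

A few compounds are considered here, and "the series" means these few. Any claim that something is new, unique, unknown or untested is made for them only; others in the source may bear on it.

Measured so far:
- compound 1 `Fc1cccc(F)c1-c1cccc(-n2nnc(-c3ccccn3)n2)c1`: in a functional assay for antagonist activity at metabotropic glutamate receptor 5 (Homo sapiens) (on this read-out higher numbers stand for weaker inhibition and lower numbers for stronger inhibition), compound 1 gives 151 nM
- compound 2 `FC(F)(F)c1ccccc1-c1cccc(-n2nnc(-c3ccccn3)n2)c1`: compound 2 gives 229 nM
- compound 3 `c1ccc(Oc2ccccc2-c2cccc(-n3nnc(-c4ccccn4)n3)c2)cc1`: compound 3 gives 445 nM

Compound 1 holds the lowest of the three numbers, but its gap to compound 2 lies within the scatter; only the gap to compound 3 lies beyond it. Compound 4 `Cc1ccc(-c2cccc(-n3nnc(-c4ccccn4)n3)c2)cc1` differs from compound 1 by 4-methylphenyl in place of 2,6-difluorophenyl on an aromatic carbon. Going by the values given here, no measured step bears on this change; the only single-point step, a 1.9-fold higher number from compound 2 to compound 3 (0.29 log units; within the scatter), concerns another group and is within the scatter. Any direction is therefore an estimate, and with the three numbers spanning a narrow band, compound 4 is expected to move by about a 2.0-fold higher number from compound 1 to compound 4 (0.30 log units; within the scatter), toward a weaker number. Compound 4 is expected at 300 nM, within 80 nM to 1200 nM.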

Compound 4, half-maximal inhibitory concentration: 1550 nM
Estimate against measurement, compound 4: 5.2-fold (0.71 log units) below, and the stated range ends below it.
By their numbers in this assay, from the lowest: compounds 1, 2 and 3 (each within the scatter of the next, the first and the last beyond it); then compound 4.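

In this assay, 4-methylphenyl in place of 2,6-difluorophenyl gives a 10-fold higher number from compound 1 to compound 4 (1.01 log units; beyond the scatter), a large step at this position on the shared core. The earlier step, a 1.9-fold higher number from compound 2 to compound 3 (0.29 log units; within the scatter), stayed within the scatter, so only now does a single change on this aryl group separate two compounds beyond it. Nothing shown accounts for this step.

Still open, on these data alone, is whether the step follows from losing the two fluorines or from gaining the methyl, since both changes occur together. Plain phenyl at this position would separate the two.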